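This account rests on a few compounds, and the source may have more. Where it says the series, first, only, none or still open, it means among the compounds named here.

Compound 1 `Oc1cccc(-c2cc(-c3ccc(Cl)cc3)nc(-c3cccs3)c2)c1` gives 15.1% in an assay on isolated protein for inhibition of DNA topoisomerase 1 (Homo sapiens), with a stated time of 30 min, tested at 100 uM; a lower number here means a weaker effect, a higher number a stronger effect of the compound at the concentration tested. Compound 2 `Oc1cccc(-c2cc(-c3ccc(Cl)cc3)nc(-c3cccnc3)c2)c1` gives 2.8%. Compound 3 `Oc1cccc(-c2cc(-c3ccc(Cl)cc3)nc(-c3ccccn3)c2)c1` gives 30%.

Compound 3 stands highest of these three: a number 14.9 percentage points higher from compound 1 to compound 3 (beyond the scatter) and a number 27.2 percentage points higher from compound 2 to compound 3 (beyond the scatter), both beyond the usual scatter. Compound 4 `Oc1cccc(-c2cc(-c3ccncc3)nc(-c3ccc(Cl)cc3)c2)c1` differs from compound 3 in one place: pyridin-4-yl in place of pyridin-2-yl on an aromatic carbon. The measured steps that bear on this are the exchanges among the aromatic rings at that position. Moving the ring nitrogen away from the attachment point lowered the number: a number 12.3 percentage points lower from compound 1 to compound 2 (beyond the scatter), and a number 27.2 percentage points higher from compound 2 to compound 3 (beyond the scatter) in the reverse direction. The change to compound 4 again moves the nitrogen away from the attachment point, so a modest downward step is expected, a number 22 percentage points lower from compound 3 to compound 4 (beyond the scatter). Compound 4 is therefore estimated at 8%, with a range from 0% to 25%.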

Compound 4, a percentage reported as inhibition, at one concentration (the size of the read-out at that concentration, not a potency): 8%
Compound 4: the middle estimate sits on the measured number at the digits printed, and the stated range covers the measured number.
By their numbers in this assay, from the lowest: compounds 2, 4 and 1 (each within the scatter of the next, the first and the last beyond it); then compound 3.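

In this assay, among these compounds, the new compound shows that pyridin-2-yl is the only ring at this position so far that stands apart from the others: a number 22 percentage points lower from compound 3 to compound 4 (beyond the scatter). Pyridin-4-yl shows no clear separation from the other two rings, with a number 5.2 percentage points higher from compound 2 to compound 4 (within the scatter) and a number 7.1 percentage points lower from compound 1 to compound 4 (within the scatter). Nothing available explains why the place of the ring nitrogen matters here.

Still open, as far as these compounds go, is whether a ring is needed here at all. An amine, a carboxylic acid or a longer chain at this position could show this, as could a pyridin-2-yl ring carrying a methyl group.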